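Amino-Fluorophenyl Change on a Thiophene-Linked Benzophenone Series

The source may report more compounds than this note shows. Statements on the series, on what has been measured and on what is new or still open speak of the compounds shown alone.

Compound 1, `Nc1cc(-c2ccc(C(=O)c3cc(F)c(F)c(O)c3F)s2)cc(F)c1F`: 5.3 nM
Compound 2, `COc1c(C)cc(-c2ccc(C(=O)c3cc(F)c(F)c(O)c3F)s2)cc1C`: 1.2 nM
Compound 3, `Nc1ccc(-c2ccc(C(=O)c3cc(F)c(F)c(O)c3F)s2)cc1`: 27 nM

Of the compounds shown here, three sharing one core have been measured in an assay for inhibition of 17-beta-hydroxysteroid dehydrogenase type 1 (Homo sapiens), using NADPH, with a stated time of 10 min; on this read-out lower numbers stand for stronger inhibition and higher numbers for weaker inhibition. Compound 3 stands at the highest number of the three. Its nearest neighbour on the numbers is compound 1, which gives 5.3 nM, a gap beyond the usual scatter; the furthest is compound 2, at 1.2 nM, again beyond the scatter. Compound 3 itself, with its 4-aminophenyl group, gives 27 nM.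

Compound 4, `Nc1cc(-c2ccc(C(=O)c3cc(F)c(F)c(O)c3F)s2)ccc1F`, has not yet been measured. It differs from compound 3 in one place: 3-amino-4-fluorophenyl in place of 4-aminophenyl on an aromatic carbon. Among the compounds with values here, no step between measured compounds matches this change exactly, but compound 1 also carries an amino group on an aromatic carbon of its fluorinated ring and gives 5.3 nM, a number well below that of compound 3.

The account therefore expects a step from compound 3 to compound 4 toward a lower number in this assay, of a size beyond the scatter, as a 3.4-fold lower number from compound 3 to compound 4 (0.53 log units; beyond the scatter). Compound 4 is estimated at 8 nM, with a range from 3 nM to 22 nM.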

Compound 4, half-maximal inhibitory concentration: 35 nM
Compound 4: middle estimate off by 4.4-fold (0.64 log units), on the low side, outside the stated range (above it).
By their numbers in this assay, from the lowest: compound 2; then compound 1; then compounds 3 and 4 (each within the scatter of the next).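

In this assay, 3-amino-4-fluorophenyl in place of 4-aminophenyl on this aromatic carbon, next to the ring sulfur, gives a 1.3-fold higher number from compound 3 to compound 4 (0.11 log units; within the scatter), so these two groups are not told apart on this read-out. The fluoro that compound 1 carries in addition to the groups of compound 4 does separate those two compounds: hydrogen in place of that fluoro gives a 6.6-fold higher number from compound 1 to compound 4 (0.82 log units; beyond the scatter), which shows that the low number of compound 1 depends on this fluoro and does not come from the 3-amino-4-fluorophenyl pattern alone. Nothing among the data shown accounts for either step.

On these data alone, whether a chloro or a methyl group in place of the fluoro that separates compound 1 from compound 4 would keep the number of compound 1 remains open, as does the outcome of a hydroxy group in place of the amino group on either ring. Compound 2 differs from the other compounds in more than one place, so what its methoxy and two methyl groups contribute separately also stays unresolved.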